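The compounds below may be only part of what the source reports. "The series", "measured", "known", "first", "only" and "open" are said of these compounds alone.

Compound 1, `N#Cc1ccc(Nc2nc(Oc3ccnc4ccccc34)nc(N3CCN(C(c4ccccc4)c4ccc(Cl)cc4)CC3)n2)cc1C(F)(F)F`: > 100000 nM
Compound 2, `CCN1CCN(c2nc(Nc3ccc(C#N)c(C(F)(F)F)c3)nc(Oc3ccnc4ccccc34)n2)CC1`: 86600 nM

Both measured compounds share the same core and were tested in a functional assay on DU-145 cells (Homo sapiens) for cytotoxicity, read by sulforhodamine B assay, with a stated time of 48 h; on this read-out lower numbers stand for stronger inhibition of growth and higher numbers for weaker inhibition of growth. Compound 2 gives 86600 nM there. For compound 1 the assay reports only a limit, > 100000 nM, and not a number. Compound 1 thus sits at the limit of > 100000 nM in this assay, at which 1 of the 2 values shown sits, so its exact place relative to compound 2 cannot be read off; both values lie in a region of very weak growth inhibition.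

Compound 3, `N#Cc1ccc(Nc2nc(Oc3ccnc4ccccc34)nc(N3CCN(C(c4ccccc4)c4ccccc4)CC3)n2)cc1C(F)(F)F`, differs from compound 1 by a single change: hydrogen in place of chloro on an aromatic carbon. Within the data shown here, no pair of measured compounds shows this change, so no measured step guides it. Removing one chlorine is expected to move this assay by no more than the usual scatter, in no particular direction. The expected step is a number no higher from compound 1 to compound 3 (the limit leaves the size open). Compound 3 is therefore estimated at 100000 nM, with a range from 30000 nM to 300000 nM, and the assay may again report only a limit.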

Compound 3, concentration for 50% growth inhibition: > 100000 nM
Compound 3 ended at the assay's limit (the forecaster's own chance of this, stated with the estimate: 60%); the middle value sits exactly at the limit.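

Compound 1 and compound 3 both end at a limit of this assay and not at a number, so no step can be read between them: the limit of > 100000 nM in this assay, at which 2 of the 3 values shown sit.

The compounds shown leave open whether the change from 4-chlorophenyl to phenyl alters growth inhibition in this assay at all.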